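Hydroxy to Dimethylamino in an Antiproliferative Series

A few compounds are considered here, and "the series" means these few. Any claim that something is new, unique, unknown or untested is made for them only; others in the source may bear on it.

Within the data shown here, in a functional assay on HCT-8 cells (Homo sapiens) for antiproliferative activity, read by MTT assay, with a stated time of 48 h (on this read-out higher numbers stand for weaker inhibition and lower numbers for stronger inhibition), compound 1 (`COc1ccc(C(=O)c2ccc(OC)c3c2OC(C)(C)C=C3)c(NC(=O)CO)c1`) gives 230 nM as the lower of the two numbers measured so far. Compound 2 (`COc1ccc(C(=O)c2ccc(OC)c3c2C=CC(C)(C)O3)c(NC(=O)CN)c1`) gives 1050 nM and lies higher, with a gap beyond the usual scatter. The two compounds are not linked by a change in one place, so the gap cannot be tied to any single structural feature.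

Compound 3 (`COc1ccc(C(=O)c2ccc(OC)c3c2OC(C)(C)C=C3)c(NC(=O)CN(C)C)c1`) has not yet been measured. It keeps the core of compound 1 and changes one group (dimethylamino in place of hydroxy on a saturated chain carbon bound to a carbonyl carbon), with dimethylamino in place of hydroxy on a saturated chain carbon bound to a carbonyl carbon. Among the measured compounds shown here, no measured pair shows this change, so the expectation remains loose. With compound 1 at 230 nM as the lowest number available, a moderate move toward weaker inhibition in this assay is expected, although a step within the scatter cannot be ruled out. The estimated step (a 2.2-fold higher number from compound 1 to compound 3 (0.34 log units; beyond the scatter)) is therefore modest and uncertain. Compound 3 is estimated at 500 nM with an expected range from 130 nM to 2000 nM in this measurement.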

Compound 3, half-maximal inhibitory concentration: 1590 nM
For compound 3 the middle estimate is 3.2-fold (0.50 log units) below the measured one, and the stated range covers the measured number.
By their numbers in this assay, from the lowest: compound 1; then compounds 2 and 3 (each within the scatter of the next).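

In this assay, dimethylamino in place of hydroxy on a saturated chain carbon bound to a carbonyl carbon gives a 6.9-fold higher number from compound 1 to compound 3 (0.84 log units; beyond the scatter). Among these compounds, this is the first step here that changes one place only, so unlike the earlier gap, it can be tied to a single structural feature, and it shows that this position is sensitive to the group it carries, with the change on the core of compound 1 moving the number toward weaker inhibition beyond the scatter. The change replaces a group counted with a hydrogen-bond donor by one counted with none and also adds heavy atoms, but no measurement here explains the step.

These two differences remain unseparated, and this single pair sets no trend for the position. Methoxy or methylamino on the same carbon would show how other groups fare there, while a longer chain carrying the hydroxy or a carboxylic acid in its place would test how much more this position tolerates on the core of compound 1.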